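The compounds below may be only part of what the source reports. "The series", "measured", "known", "first", "only" and "open" are said of these compounds alone.

Compound 1 `COc1cccc(NC(=S)Nc2cccc(C(F)(F)F)c2)c1`: 20000 nM
Compound 2 `CCCCc1ccc(NC(=S)Nc2cccc(C(F)(F)F)c2)c(C)c1`: 18000 nM
Compound 3 `O=C(NC(=S)Nc1cccc(C(F)(F)F)c1)[C@H]1C[C@@H]2CC[C@H]1C2`: 20000 nM

In an ADME assay on Vero 76 cells (Chlorocebus sabaeus) for cytotoxicity, read by crystal violet staining, with a stated time of 96 h (on this read-out lower numbers stand for higher toxicity in this test and higher numbers for lower toxicity in this test), compound 1 gives 20000 nM, the same number at the digits shown as compound 3, and compound 2 sits within the scatter of both, so the three measured compounds cannot be told apart on this read-out.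

Compound 4 `Fc1cccc(NC(=S)Nc2cccc(C(F)(F)F)c2)c1` has not been measured. It differs from compound 1 in one place: fluoro in place of methoxy on an aromatic carbon, meta to a large group. Within the data shown here, no measured pair changes this position, so nothing measured points in either direction. Because compound 2 at 18000 nM and compound 3 at 20000 nM lie so close to compound 1, the expected step of no change at the digits printed from compound 1 to compound 4 (within the scatter) is none beyond the scatter. Compound 4 is estimated at 20000 nM, with a range from 10000 nM to 40000 nM.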

Compound 4, half-maximal cytotoxic concentration: 20000 nM
Estimate against measurement, compound 4: no gap at the digits printed; low and high end bracket the measured number.
By their numbers in this assay, from the lowest: compounds 2, 1, 3 and 4 (each within the scatter of the next).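

In this assay the swap of methoxy for fluoro on an aromatic carbon, meta to a large group, gives no change at the digits printed from compound 1 to compound 4 (within the scatter) and so provides the first step read at this position. This one swap leaves the number unmoved, so on this read-out the two groups cannot be told apart here. No measurement at hand explains this result. From the compounds shown here alone, whether an amine, a carboxylic acid or a longer chain at this position would shift the number stays open. So does whether fluoro gives the same result on other aromatic carbons of the ring.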